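A few compounds are considered here, and "the series" means these few. Any claim that something is new, unique, unknown or untested is made for them only; others in the source may bear on it.

For the measured compounds named here, compound 1 `CCOC(=O)C(=O)Nc1cccccc1=O` gives 80% in a functional assay on the whole organism (strain Sprague-Dawley CD) for inhibition, with Rattus norvegicus as the target, read by paw edema, at a dose of 10 mg/kg by the intraperitoneal route (a higher number here means a stronger effect of the compound at the dose given, a lower number a weaker effect), the highest of the three numbers measured so far. Compound 3 `CCOC(=O)C(=O)Nc1ccccc(NC)c1=O` gives 73%, and the step of a number 7 percentage points lower from compound 1 to compound 3 (within the scatter) lies within the scatter. Compound 2 `CCOC(=O)C(=O)Nc1ccccc(OC)c1=O` gives 24%, with a number 56 percentage points lower from compound 1 to compound 2 (beyond the scatter) a large drop; the return a number 49 percentage points higher from compound 2 to compound 3 (beyond the scatter) is likewise large.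

Compound 4 `CCOC(=O)C(=O)Nc1ccc(NC(=O)C(=O)OCC)c(=O)cc1` carries the change (((ethoxycarbonyl)carbonyl)amino in place of hydrogen on an aromatic carbon). Both earlier steps bear on it: substitution on the ring can cost much, as in a number 56 percentage points lower from compound 1 to compound 2 (beyond the scatter), or nothing beyond the scatter, as with the nitrogen-linked group in a number 7 percentage points lower from compound 1 to compound 3 (within the scatter). A moderate decrease is therefore expected, a number 25 percentage points lower from compound 1 to compound 4 (beyond the scatter), since the entering group is also nitrogen-linked yet far larger. For compound 4 the estimate is 55%, range 20% to 85%.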

Compound 4, a percentage reported as inhibition, in the whole organism at one dose (the size of the read-out at that dose, not a potency): 93%
Compound 4: middle estimate off by 38 percentage points, on the low side; the measured number lies above the stated range.
By their numbers in this assay, from the lowest: compound 2; then compounds 3 and 1 (each within the scatter of the next); then compound 4.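

In this assay, the aromatic carbon three ring bonds from the ring atom that bears a ((ethoxycarbonyl)carbonyl)amino group accepts a second such group, and a number 13 percentage points higher from compound 1 to compound 4 (beyond the scatter) is a modest gain. Substitution on the ring therefore need not cost effect and can add to it, although methoxy in compound 2 goes against any general rule. Nothing at hand accounts for this gain. As far as these compounds go, it remains open whether a plain amine or a carboxylic acid at this carbon would keep the gain, and whether the ethyl ester of the entering group is needed for it.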